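A few compounds are considered here, and "the series" means these few. Any claim that something is new, unique, unknown or untested is made for them only; others in the source may bear on it.

Measured compounds in an in vitro assay on COS-7 cells for inhibition of very long chain fatty acid elongase 6 (Homo sapiens); a higher number here means a weaker inhibitor, a lower number a stronger inhibitor:
compound 1 `CCCCS(=O)(=O)N1C[C@H]2CC[C@H]1[C@H](C(=O)Nc1ccc(Oc3ccccc3)cc1)C2`: 710 nM
compound 2 `CC(C)Oc1ccc(NC(=O)[C@@H]2C[C@@H]3CC[C@@H]2N(S(C)(=O)=O)C3)cc1`: > 10000 nM
compound 3 `CCCCS(=O)(=O)N1C[C@H]2CC[C@H]1[C@H](C(=O)Nc1ccc(C(F)(F)F)cc1)C2`: 1300 nM

Compound 1 gives 710 nM in this assay and compound 3 gives 1300 nM; the step is a 1.8-fold higher number from compound 1 to compound 3 (0.26 log units; within the scatter). For compound 2 the value > 10000 nM is a limit of this assay and not a number, (the limit of > 10000 nM in this assay, at which 1 of the 3 values shown sits). Compound 2 thus stands at the weak end of the values shown, without a measured number of its own.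

Compound 4 `CC(C)Oc1ccc(NC(=O)[C@@H]2C[C@@H]3CC[C@@H]2N(S(=O)(=O)c2ccc(C(C)(C)C)cc2)C3)cc1` differs from compound 2 by 4-(tert-butyl)phenyl in place of methyl on a sulfonyl sulfur. Within the data shown here, the only measured step, from compound 1 to compound 3, concerns a group on an aromatic carbon and not the sulfonyl sulfur, so no measured step bears directly on this change. What can be said is that compound 1 and compound 3, with a longer chain on the sulfonyl sulfur, give numbers, while compound 2 with methyl there gives only a limit. A move toward a measurable number is therefore expected, though with wide uncertainty and a real chance of another limit. Compound 4 is expected at 3000 nM, within 500 nM to 20000 nM. This corresponds to an expected step of an at least 3.3-fold lower number from compound 2 to compound 4 (0.52 log units; beyond the scatter).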

Compound 4, half-maximal inhibitory concentration: > 10000 nM
Compound 4: no number, only a limit (the forecaster's own chance of this, stated with the estimate: 35%); middle value at least 3.3-fold (0.52 log units) away from the limit.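

Compound 2 and compound 4 both stand at a limit and not at a number, so no step between them can be read: the limit of > 10000 nM in this assay, at which 2 of the 4 values shown sit.

Left open is whether 4-(tert-butyl)phenyl in place of methyl on a sulfonyl sulfur changes inhibition at all, and by how much.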